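The compounds below may be only part of what the source reports. "The series", "measured", "known", "first", "only" and "open" are said of these compounds alone.

Measured in a functional assay on HCT-116 cells (Homo sapiens), read by MTT assay, with a stated time of 72 h; a higher number here means a weaker inhibitor, a lower number a stronger inhibitor:
compound 1 `CSc1ncnc2c1c(-c1ccoc1)cn2[C@@H]1O[C@H](CO)[C@@H](O)[C@H]1O`: 100 nM
compound 2 `C#Cc1cn([C@@H]2O[C@H](CO)[C@@H](O)[C@H]2O)c2ncnc(SC)c12`: 90 nM
compound 3 `CNc1ncnc2c1c(-c1ccco1)cn2[C@@H]1O[C@H](CO)[C@@H](O)[C@H]1O`: 440 nM

Compound 3 has the highest number of the three, and the values of compound 1 and compound 2 both lie beyond the scatter below it. Next is compound 4 `CNc1ncnc2c1c(-c1ccoc1)cn2[C@@H]1O[C@H](CO)[C@@H](O)[C@H]1O`, with furan-3-yl in place of furan-2-yl on an aromatic carbon. Among the compounds with values here, no measured step isolates this swap. The closest guide is a change on the same carbon, a 1.1-fold lower number from compound 1 to compound 2 (0.05 log units; within the scatter), so no shift beyond the scatter is expected in this assay. The expected step is small: a 1.4-fold lower number from compound 3 to compound 4 (0.14 log units; within the scatter). Compound 4 is estimated at 320 nM, with an expected range of 110 nM to 900 nM.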

Compound 4, half-maximal inhibitory concentration: > 20000 nM
Compound 4: a limit, no number (the forecaster's own chance of this, stated with the estimate: 3%); middle value at least 62-fold (1.79 log units) from the limit.
By their numbers in this assay, from the lowest: compounds 2 and 1 (each within the scatter of the next); then compound 3. At a limit, above all of these: compound 4.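

In this assay, furan-3-yl in place of furan-2-yl on this aromatic carbon is far from silent when methylamino is the other group (an at least 45-fold higher number from compound 3 to compound 4 (1.65 log units; beyond the scatter)). With furan-3-yl held fixed, methylamino in place of methylsulfanyl is just as decisive (an at least 200-fold higher number from compound 1 to compound 4 (2.30 log units; beyond the scatter)), so furan-3-yl is not poorly placed on its own, and the outcome depends on the pairing. Compound 4 stands at a limit of the assay, not a number: the limit of > 20000 nM in this assay, at which 1 of the 4 values shown sits. Open, from the compounds shown here alone, is whether furan-2-yl gives any gain with methylsulfanyl. Also open, going by these compounds, is whether a plain amino or dimethylamino group in place of methylamino would behave the same way with furan-3-yl.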